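From Compound 3 to Compound 4: Keeping a Hydroxy Group

The source may hold more compounds than are shown below. What is called first, only, known or untested is meant among the compounds shown, and "the series" means these compounds.

Of the compounds shown here, three sharing one core have been measured in a functional assay on A549 cells (Homo sapiens) for cytotoxicity, read by MTT assay, with a stated time of 72 h; a higher number here means a weaker inhibitor, a lower number a stronger inhibitor. Compound 1 `COc1ccc(/C=C2\CCC/C(=C\c3cccc(Br)c3)C2=O)cc1OC` gives 12800 nM, while compound 3 `COc1ccc(/C=C2\CCC/C(=C\c3cccc(O)c3)C2=O)cc1OC` gives 4300 nM, the lower of the two actual numbers. Compound 2 `COc1ccccc1/C=C1\CCC/C(=C\c2ccc(OC)c(OC)c2)C1=O` reads > 20000 nM, which is a limit of the assay and not a number.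

The next structure, compound 4 `COc1cc(/C=C2\CCC/C(=C\c3ccc(OC)c(OC)c3)C2=O)ccc1O`, is still unmeasured, and its change is 4-hydroxy-3-methoxyphenyl in place of 3-hydroxyphenyl on a double-bonded chain carbon bound to a double-bonded ring carbon. The hydroxy group therefore stays, now as part of 4-hydroxy-3-methoxyphenyl. Going by the values given here, two measured steps bear on this. Hydroxy in place of bromo gave a 3.0-fold lower number from compound 1 to compound 3 (0.47 log units; beyond the scatter), and 3-hydroxyphenyl in place of 2-methoxyphenyl gave an at least 4.6-fold lower number from compound 2 to compound 3 (0.66 log units; beyond the scatter). Both favour keeping a hydroxy group, but neither step tests adding a methoxy group to a ring that already has one. A small move towards a higher number therefore seems more likely than a clear gain. The estimated change is a 1.4-fold higher number from compound 3 to compound 4 (0.14 log units; within the scatter), and no step beyond the scatter is expected. For compound 4 the estimate is 6000 nM, with an expected range from 2000 nM to 18000 nM.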

Compound 4, half-maximal inhibitory concentration: 10300 nM
Estimate against measurement, compound 4: 1.7-fold (0.23 log units) below, within the range that was stated.
By their numbers in this assay, from the lowest: compound 3; then compounds 4 and 1 (each within the scatter of the next). At a limit, above all of these: compound 2.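

In this assay, a hydroxy group on this ring does not by itself keep the gain: 4-hydroxy-3-methoxyphenyl in place of 3-hydroxyphenyl gives a 2.4-fold higher number from compound 3 to compound 4 (0.38 log units; beyond the scatter). Set against 3-bromophenyl, the same group gives a 1.2-fold lower number from compound 1 to compound 4 (0.09 log units; within the scatter) and so brings no change beyond the scatter, even though it carries a hydroxy group. Against 2-methoxyphenyl only a floor can be given, an at least 1.9-fold lower number from compound 2 to compound 4 (0.28 log units; that floor lies within the scatter), and the value behind that floor is a limit of the assay and not a number: the limit of > 20000 nM in this assay, at which 1 of the 4 values shown sits.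

Compound 4 both adds a methoxy group and carries its hydroxy group under a different name, 4-hydroxy rather than 3-hydroxy, so the compounds shown cannot separate these two changes. Also open, as far as these compounds go, is how an amine or a carboxylic acid at this place would read in this assay.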